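Methyl for fluoro on the urea terminus, second pair

This account rests on a few compounds, and the source may have more. Where it says the series, first, only, none or still open, it means among the compounds named here.

Compound 3 `CCN(CC)CCNc1nc(-c2ccc(NC(=O)Nc3ccc(F)cc3)cc2)nc2c(Cl)c(Cl)sc12` gives 500 nM in a functional assay on NCI-H460 cells (Homo sapiens) for cytotoxicity, read by MTT assay, with a stated time of 72 h (on this read-out lower numbers stand for stronger inhibition and higher numbers for weaker inhibition), the second highest of the three numbers in hand. Its nearest neighbour is compound 1 `CCN(CC)CCCNc1nc(-c2ccc(NC(=O)Nc3ccc(F)cc3)cc2)nc2c(Cl)c(Cl)sc12` at 450 nM, and a 1.1-fold higher number from compound 1 to compound 3 (0.05 log units; within the scatter). Furthest away stands compound 2 `CCN(CC)CCCNc1nc(-c2ccc(NC(=O)Nc3ccc(C)cc3)cc2)nc2c(Cl)c(Cl)sc12` at 1240 nM. Compound 4 `CCN(CC)CCNc1nc(-c2ccc(NC(=O)Nc3ccc(C)cc3)cc2)nc2c(Cl)c(Cl)sc12` differs from compound 3 by methyl in place of fluoro on an aromatic carbon. Going by the values given here, the one measured step of the same kind is a 2.8-fold higher number from compound 1 to compound 2 (0.44 log units; beyond the scatter), and nothing else in the set bears on this change. For compound 4 a modest rise in the number, beyond the scatter, is therefore expected, namely a 2.8-fold higher number from compound 3 to compound 4 (0.45 log units; beyond the scatter). For compound 4 the expected value in this assay is 1400 nM, with a range of 800 nM to 2600 nM.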

Compound 4, half-maximal inhibitory concentration: 840 nM
The estimate for compound 4 lay 1.7-fold (0.22 log units) above the measured number; measured number inside the range.
By their numbers in this assay, from the lowest: compounds 1, 3, 4 and 2 (each within the scatter of the next, the first and the last beyond it).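

On the core of compound 3, 4-fluorophenyl to 4-methylphenyl gives a 1.7-fold higher number from compound 3 to compound 4 (0.23 log units; within the scatter), so the change stays within the scatter here, whereas on the core of compound 1 it lay beyond it. The two readings still agree: the same change on two cores in this assay, a 2.8-fold higher number (0.44 log units; beyond the scatter) from compound 1 to compound 2 and a 1.7-fold higher number (0.23 log units; within the scatter) from compound 3 to compound 4, 1.6-fold (0.21 log units) apart, within the scatter of two such steps Diethylamino in place of (diethylamino)methyl, now also read with 4-methylphenyl, gives a 1.5-fold lower number from compound 2 to compound 4 (0.17 log units; within the scatter), and it stays within the scatter with either terminal group: the same change on two cores in this assay, a 1.1-fold higher number (0.05 log units; within the scatter) from compound 1 to compound 3 and a 1.5-fold lower number (0.17 log units; within the scatter) from compound 2 to compound 4, 1.6-fold (0.21 log units) apart, within the scatter of two such steps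

Open, as far as these compounds go, is how methoxy, chloro or trifluoromethyl would read at this place on the ring. Also open, from the compounds shown here alone, is whether a longer chain or a cyclic amine in place of diethylamino would move the number beyond the scatter.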